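From Bromo to Fluoro on the Methyl Ester

The compounds below may be only part of what the source reports. "The series", "measured", "known", "first", "only" and "open" are said of these compounds alone.

In an ADME assay on a cell-free system (plasma, Rattus norvegicus, strain Sprague-Dawley) for metabolic stability, read by LC-MS, with a stated time of 120 min, tested at 1 uM (on this read-out lower numbers stand for a less stable compound and higher numbers for a more stable compound), compound 1 `CC#CCn1c(N2CCC[C@@H](N)C2)cc(=O)n(Cc2ccc(Cl)c(C(=O)O)c2)c1=O` gives 27.8% while compound 2 `CC#CCn1c(N2CCC[C@@H](N)C2)cc(=O)n(Cc2ccc(Br)c(C(=O)OC)c2)c1=O` gives 82.7% as the higher of the two numbers, a gap beyond the scatter. Compound 3 `CC#CCn1c(N2CCC[C@@H](N)C2)cc(=O)n(Cc2ccc(F)c(C(=O)OC)c2)c1=O` differs from compound 2 by a single exchange fluoro in place of bromo on an aromatic carbon with fluoro in place of bromo on an aromatic carbon. Within the data shown here, no measured pair shows this exchange alone, so the size of its effect remains uncertain. In this assay a fall beyond the scatter is expected, with an estimated a number 20.7 percentage points lower from compound 2 to compound 3 (beyond the scatter) for this exchange. Compound 3 is expected at 62% with an estimated range from 38% to 82% on this read-out.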

Compound 3, percent of the compound remaining: 81.8%
Estimate against measurement, compound 3: 19.8 percentage points below; measured number inside the range.
By their numbers in this assay, from the lowest: compound 1; then compounds 3 and 2 (each within the scatter of the next).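

In this assay the exchange of bromo for fluoro on the aromatic carbon ortho to the methoxycarbonyl group gives a number 0.9 percentage points lower from compound 2 to compound 3 (within the scatter) and so sets the two halogens apart by nothing beyond the scatter. With the methyl ester kept, this position therefore accepts either halogen on this read-out. No measurement at hand bears on the reason for this.

As far as these compounds go, whether a nitrile or an amine on this carbon would read the same stays open. So does the step from methyl ester to carboxylic acid with the halogen held fixed.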